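Adding Chlorine to the Fluorinated Analogue

The source may hold more compounds than are shown below. What is called first, only, known or untested is meant among the compounds shown, and "the series" means these compounds.

Three compounds have been measured in an assay on cells for inhibition of histone deacetylase 4 (Homo sapiens), read by fluorescence, with a stated time of 30 min; on this read-out lower numbers stand for stronger inhibition and higher numbers for weaker inhibition:

Compound 1, `O=C1NC(=O)/C(=C\c2ccc(OCC(=O)N3N=C(c4ccccc4)CC3c3ccccc3)cc2)S1`, gives 1600 nM.
Compound 2, `O=C1NC(=O)/C(=C\c2ccc(OCC(=O)N3N=C(c4ccccc4)CC3c3ccccc3Cl)cc2)S1`, gives 1200 nM.
Compound 3, `O=C1NC(=O)/C(=C\c2ccc(OCC(=O)N3N=C(c4ccc(F)cc4)CC3c3ccccc3)cc2)S1`, gives 4200 nM.

Of these three, compound 3 gives the highest number, so on this read-out it is the weakest inhibitor measured so far; the nearest to it is compound 1, and the step between them is a 2.6-fold higher number from compound 1 to compound 3 (0.42 log units; beyond the scatter).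

The next compound, compound 4, `O=C1NC(=O)/C(=C\c2ccc(OCC(=O)N3N=C(c4ccc(F)cc4)CC3c3ccccc3Cl)cc2)S1`, differs from compound 3 in one place: chloro in place of hydrogen on an aromatic carbon. The same change has already been made once in this set, from compound 1 to compound 2, and there it gave a 1.3-fold lower number from compound 1 to compound 2 (0.12 log units; within the scatter), a step too small to be told apart from repeat measurements. Among the measured compounds shown here, with only that one precedent to go on, no step beyond the scatter is expected here either, and the estimated step is a 1.2-fold lower number from compound 3 to compound 4 (0.08 log units; within the scatter). Compound 4 is therefore expected to give about 3500 nM, with a likely range from 1500 nM to 8000 nM.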

Compound 4, half-maximal inhibitory concentration: 1100 nM
Beside the measured number, compound 4's estimate is 3.2-fold (0.50 log units) above it; measured number outside the range, below it.
By their numbers in this assay, from the lowest: compounds 4, 2 and 1 (each within the scatter of the next); then compound 3.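

In this assay, the change from phenyl to 2-chlorophenyl turns out not to have a fixed size, because its effect depends on the core that carries it: the same change on two cores in this assay, a 1.3-fold lower number (0.12 log units; within the scatter) from compound 1 to compound 2 and a 3.8-fold lower number (0.58 log units; beyond the scatter) from compound 3 to compound 4, 2.9-fold (0.46 log units) apart, beyond the scatter of two such steps. The fluoro change behaves the same way: with the chloro group already present it gives a 1.1-fold lower number from compound 2 to compound 4 (0.04 log units; within the scatter), so the rise in number seen without chloro does not appear: the same change on two cores in this assay, a 2.6-fold higher number (0.42 log units; beyond the scatter) from compound 1 to compound 3 and a 1.1-fold lower number (0.04 log units; within the scatter) from compound 2 to compound 4, 2.9-fold (0.46 log units) apart, beyond the scatter of two such steps. On these four compounds, then, the two changes do not simply add up, and the chloro group matters most where the fluoro group is present, with a 3.8-fold lower number from compound 3 to compound 4 (0.58 log units; beyond the scatter).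

Still open, as far as these compounds go, is whether this dependence belongs to chloro itself or would also appear with a methyl or methoxy group at this place. The compounds shown also cannot tell why the two changes depend on each other.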